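The compounds below may be only part of what the source reports. "The series", "measured", "known", "first", "only" and "open" are said of these compounds alone.

Measured so far in an assay on LtK cells with ATP-sensitive inward rectifier potassium channel 11 (Homo sapiens) as the target; on this read-out higher numbers stand for an effect only at larger amounts of compound and lower numbers for an effect already at smaller amounts:

Compound 1 `CC(=O)Nc1c(C(O)(C(F)(F)F)C(F)(F)F)ccc2ccccc12`: 18 nM
Compound 2 `CCCC(=O)Nc1c(C(O)(C(F)(F)F)C(F)(F)F)ccc2ccccc12`: 131 nM
Compound 3 `O=C(Nc1c(C(O)(C(F)(F)F)C(F)(F)F)ccc2ccccc12)C1CCCC1`: 495 nM

Compound 3 gives the highest of these three numbers in this assay, so it acts only at larger amounts than the other two. The steps that reach it both enlarge the group on the carbonyl carbon: a 28-fold higher number from compound 1 to compound 3 (1.44 log units; beyond the scatter) and a 3.8-fold higher number from compound 2 to compound 3 (0.58 log units; beyond the scatter). Compound 4 `O=C(Nc1c(C(O)(C(F)(F)F)C(F)(F)F)ccc2ccccc12)c1cccc(Cl)c1` carries the change (3-chlorophenyl in place of cyclopentyl on a carbonyl carbon). Here the group on the carbonyl carbon grows again, which in the measured steps went with higher numbers, but no measured step exchanges a saturated ring for an aromatic one, so those steps bear on this change only loosely. A modest step at most is therefore expected, more likely upward than downward, and it may well stay within the scatter: a 1.4-fold higher number from compound 3 to compound 4 (0.15 log units; within the scatter). For compound 4 the estimate in this assay is 700 nM, with a range from 150 nM to 3000 nM.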

Compound 4, half-maximal effective concentration: 98 nM
Estimate against measurement, compound 4: 7.1-fold (0.85 log units) above, outside the stated range (below it).
By their numbers in this assay, from the lowest: compound 1; then compounds 4 and 2 (each within the scatter of the next); then compound 3.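

In this assay, the link between a larger group on the carbonyl carbon and a higher number breaks at this position: 3-chlorophenyl has more heavy atoms than cyclopentyl, yet the change gives a 5.1-fold lower number from compound 3 to compound 4 (0.70 log units; beyond the scatter). So the rise seen across compounds 1, 2 and 3 does not extend to compound 4, which goes against that pattern, and the kind of ring matters here as well as the size of the group. The 3-chlorophenyl and propyl groups cannot be told apart, with a 1.3-fold lower number from compound 2 to compound 4 (0.13 log units; within the scatter), while the methyl group of compound 1 keeps the lowest number, with a 5.4-fold higher number from compound 1 to compound 4 (0.74 log units; beyond the scatter); nothing at hand explains these differences.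

Open, from the compounds shown here alone, is whether the aromatic ring or its chlorine accounts for the drop, which a plain phenyl group would help separate. Also open, going by these compounds, is whether another small group on the carbonyl carbon, such as cyclopropyl or methoxy, would match methyl.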